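The compounds below may be only part of what the source reports. "The series", "measured", "known", "first", "only" and "open" are said of these compounds alone.

Compound 1 `CC(C)n1c(/C=C2/C(=O)Nc3ccccc32)nc2ccccc21`: 38100 nM
Compound 2 `CC(C)n1c(/C=C2/C(=O)Nc3ccc(Cl)cc32)nc2ccccc21`: 36400 nM

Going by the values given here, in a functional assay on DU-145 cells (Homo sapiens) for cytotoxicity, read by MTT assay, with a stated time of 48 h (a higher number here means a weaker inhibitor, a lower number a stronger inhibitor), compound 2 gives 36400 nM, and the only measured step, a 1.0-fold lower number from compound 1 to compound 2 (0.02 log units; within the scatter), lies within the scatter, so compound 2 and compound 1 stand level. Compound 3 `CCn1c(/C=C2/C(=O)Nc3ccc(Cl)cc32)nc2ccccc21` differs from compound 2 by hydrogen in place of methyl on a saturated chain carbon bound to an aromatic nitrogen and a saturated chain carbon, which is isopropyl to ethyl. Among the compounds with values here, the single measured step concerns chloro in place of hydrogen on an aromatic carbon and does not bear on this change; no measured pair does. Lacking such a pair, the expected step of a 1.0-fold lower number from compound 2 to compound 3 (0.00 log units; within the scatter) is none beyond the scatter. Compound 3 is therefore estimated at 36000 nM, ranging from 15000 nM to 90000 nM.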

Compound 3, half-maximal inhibitory concentration: > 50000 nM
Compound 3: only a limit was reported; the forecaster's own chance of this, stated with the estimate: 10%; middle value at least 1.3-fold (0.14 log units) away from the limit.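

In this assay compound 3 is reported only as a limit, > 50000 nM. Isopropyl to ethyl on this carbon gives an at least 1.3-fold higher number from compound 2 to compound 3 (0.13 log units; that floor lies within the scatter), the first reading on this group, since the earlier pair changed only chloro for hydrogen on an aromatic carbon. The true size of this step stays unknown, and the reading ends at a limit of the assay: the limit of > 50000 nM in this assay, at which 1 of the 3 values shown sits.

The compounds shown leave open whether a longer chain or a terminal amine at this place would give a number clearly apart from that of the isopropyl compound.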